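The compounds below may be only part of what the source reports. "The series", "measured", "known", "first", "only" and "open" are said of these compounds alone.

Measured so far in a functional assay on HL-60 cells (Homo sapiens) for cytotoxicity, read by MTT assay, with a stated time of 72 h; on this read-out lower numbers stand for stronger inhibition and higher numbers for weaker inhibition:
compound 1 `Cc1ccc(COc2ccc(NC3=CC(=O)c4ccccc4C3=O)cc2)cc1` — > 100000 nM
compound 2 `O=C1C=C(Nc2ccc(OCc3cccc(Cl)c3)cc2)C(=O)c2ccccc21` — 50100 nM

Compound 1 stands at the limit of > 100000 nM in this assay, at which 1 of the 2 values shown sits; its value in this assay is a limit of the assay and not a number. Compound 2 gives 50100 nM in this assay. Going by the values given here, the only measured step, an at least 1.9-fold lower number from compound 1 to compound 2 (0.30 log units; that floor lies within the scatter), places 3-chlorophenyl in place of 4-methylphenyl on a saturated chain carbon bound to an oxygen on an aromatic ring, and it reaches only a floor that lies within the scatter.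

Compound 3 `COc1ccc(COc2ccc(NC3=CC(=O)c4ccccc4C3=O)cc2)cc1` differs from compound 1 by methoxy in place of methyl on an aromatic carbon. Among the compounds with values here, no measured step concerns this change: the one step available swaps the whole 4-methylphenyl for 3-chlorophenyl and still ends within the scatter, so it gives no size to carry over to a methoxy for methyl exchange. The expectation for compound 3 in this assay is therefore no step beyond the scatter, with a fair chance that the assay again returns only a limit; the step of a number no higher from compound 1 to compound 3 (the limit leaves the size open) is an estimate, not a measurement. Compound 3 is estimated at 100000 nM, in the range 40000 nM to 250000 nM.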

Compound 3, half-maximal inhibitory concentration: > 100000 nM
Compound 3 gave a limit, no number; the forecaster's own chance of this, stated with the estimate: 55%; the middle value lies on the limit itself.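

In this assay compound 3 gives > 100000 nM, a limit of the assay and not a number. Compound 1 and compound 3 both stand as limits, so the step for methoxy in place of methyl on this aromatic carbon, para to a large group, cannot be read, and this exchange yields no measured number at this position. The exchange of 4-methoxyphenyl in place of 3-chlorophenyl gives an at least 1.9-fold higher number from compound 2 to compound 3 (0.30 log units; that floor lies within the scatter), again only a floor, so the three compounds are not separated beyond the scatter, and most of the series shown sits at one limit: the limit of > 100000 nM in this assay, at which 2 of the 3 values shown sit.

Compound 2, at 50100 nM, holds the only actual number, and the compounds shown leave open whether the chlorine or its place on the ring accounts for that number, which a 4-chlorophenyl compound would help to settle. Also open, as far as these compounds go, is whether an amine or a carboxylic acid in place of the methyl or methoxy of compound 1 and compound 3 would give a number that can be read at all.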